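The compounds below may be only part of what the source reports. "The series", "measured", "known", "first", "only" and "open" are said of these compounds alone.

Of the compounds shown here, two have numbers so far. Compound 1 `COc1ccc(-c2c(I)c(=O)c3c(OC)cc(OC)cc3n2S(=O)(=O)c2ccc(OC)cc2)cc1` is measured in a functional assay on SEM cells (Homo sapiens) for antiproliferative activity, with a stated time of 72 h (a lower number here means that less compound is needed, a higher number that more compound is needed for the effect), where compound 1 gives 5520 nM. Compound 2 `COc1cc(OC)c2c(=O)cc(C(=O)Nc3cc(C(F)(F)F)ccc3Oc3ccccc3OC)[nH]c2c1` carries the same two methoxy groups on its core but a different side chain; in this assay compound 2 gives 10800 nM. Of the two numbers, that of compound 2 is the higher, yet the gap to compound 1 falls within the scatter of repeated measurements, so the two compounds cannot be told apart on these data.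

Compound 3 `COc1ccc(Oc2ccc(C(F)(F)F)cc2NC(=O)c2cc(=O)c3c(OC)cc(OC)cc3[nH]2)cc1` is the rearranged partner of compound 2: it has the same atoms joined differently, with 4-methoxyphenyl in place of 2-methoxyphenyl on an oxygen on an aromatic ring. Among the compounds with values here, no step between two measured compounds corresponds to such a shift of a methoxy group, so there is nothing to calibrate its size or direction. The shared core and the amide linkage stay untouched, and the two methoxy groups of the core remain where they were.

Given this, the expected outcome is a step from compound 2 to compound 3 of a 1.1-fold lower number from compound 2 to compound 3 (0.03 log units; within the scatter), that is, none beyond the scatter, with compound 3 estimated at 10000 nM and a likely range from 4000 nM to 25000 nM.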

Compound 3, half-maximal effective concentration: > 67200 nM
Compound 3 ended at the assay's limit (the forecaster's own chance of this, stated with the estimate: 10%); middle value at least 6.7-fold (0.82 log units) away from the limit.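

Replacing 2-methoxyphenyl with 4-methoxyphenyl on an oxygen on an aromatic ring, with the same atoms joined differently, gives an at least 6.2-fold higher number from compound 2 to compound 3 (0.79 log units; beyond the scatter). Within the data shown here, this shows that the number at this position depends on where the methoxy group stands and not only on which atoms are present, something that compound 1 and compound 2 alone could not show, as no step linked them. In this assay compound 3 gives > 67200 nM, which is a limit of the assay and not a number, so the step has a lower bound but no exact size: the limit of > 67200 nM in this assay, at which 1 of the 3 values shown sits.

The compounds shown leave open whether the change in compound 3 turns on the methoxy group itself, as a hydroxy group or a chlorine atom in its place on the same ring could tell, or whether a plain phenyl would stay close to compound 2. They also leave open whether the same shift of the methoxy group would give a step of similar direction with another group, such as an amine, in place of the trifluoromethyl group.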